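A few compounds are considered here, and "the series" means these few. Any claim that something is new, unique, unknown or untested is made for them only; others in the source may bear on it.

Among the measured compounds shown here, compound 2 `N#CC1=C(N)Oc2c(N)cc3nc4ccccc4nc3c2C12C(=O)N(Cc1cnnn1-c1cc(Cl)ccc1Cl)c1ccccc12` is the only member of the series with a number in a functional assay on HepG2 cells (Homo sapiens) for antiproliferative activity, read by MTT assay, with a stated time of 48 h (a lower number here means a stronger inhibitor, a higher number a weaker inhibitor), where compound 2 gives 33100 nM. Compound 1 `CC(=O)Nc1ccc(-n2nncc2CN2C(=O)C3(C(C#N)=C(N)Oc4c(N)cc5nc6ccccc6nc5c43)c3ccccc32)cc1` sits at a limit of this assay, > 50000 nM, noted as the limit of > 50000 nM in this assay, at which 1 of the 2 values shown sits. For the measured compounds named here, the one measured step, an at least 1.5-fold lower number from compound 1 to compound 2 (0.17 log units; that floor lies within the scatter), rests on that limit and says little. Compound 3 `COc1ccc(OC)c(-n2nncc2CN2C(=O)C3(C(C#N)=C(N)Oc4c(N)cc5nc6ccccc6nc5c43)c3ccccc32)c1` differs from compound 2 by 2,5-dimethoxyphenyl in place of 2,5-dichlorophenyl on an aromatic nitrogen. Going by the values given here, no step among the measured compounds bears on this change, so no shift beyond the scatter is expected; the estimated step is a 1.2-fold higher number from compound 2 to compound 3 (0.08 log units; within the scatter). Compound 3 is therefore expected at about 40000 nM, between 15000 nM and 100000 nM, with a fair chance that this assay again reports only a limit.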

Compound 3, half-maximal inhibitory concentration: 45100 nM
Beside the measured number, compound 3's estimate is 1.1-fold (0.05 log units) below it; measured number inside the range.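

In this assay, the step on this aromatic nitrogen, a 1.4-fold higher number from compound 2 to compound 3 (0.13 log units; within the scatter), shows that 2,5-dimethoxyphenyl and 2,5-dichlorophenyl are not told apart, although the entering group carries 2 hydrogen-bond acceptors and the leaving group none. The other new step, an at least 1.1-fold lower number from compound 1 to compound 3 (0.04 log units; that floor lies within the scatter), rests on a limit and cannot be read. Compound 1 gives only a limit, not a number: the limit of > 50000 nM in this assay, at which 1 of the 3 values shown sits.

Still open, from the compounds shown here alone, is whether any group at this place moves the number beyond the scatter. A phenyl bearing a carboxylic acid or an amine would test this.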